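Acyl variation on the triazene series

This account rests on a few compounds, and the source may have more. Where it says the series, first, only, none or still open, it means among the compounds named here.

Going by the values given here, compound 2 `O=C(CCl)N(/N=N/c1ccc([N+](=O)[O-])cc1Cl)c1ccc([N+](=O)[O-])cc1Cl` gives 550 nM in a functional assay on HeLa cells (Homo sapiens) for cytotoxicity, read by MTT assay, with a stated time of 72 h (a higher number here means a weaker inhibitor, a lower number a stronger inhibitor), the lowest of the two numbers so far; compound 1 `O=[N+]([O-])c1ccc(/N=N/Nc2ccc([N+](=O)[O-])cc2Cl)c(Cl)c1` gives 3010 nM. Among the compounds with values here, the only measured step, a 5.5-fold lower number from compound 1 to compound 2 (0.74 log units; beyond the scatter), concerns adding the (chloromethyl)carbonyl group, not altering it. Compound 3 `CC(=O)OCC(=O)N(/N=N/c1ccc([N+](=O)[O-])cc1Cl)c1ccc([N+](=O)[O-])cc1Cl` differs from compound 2 by acetoxy in place of chloro on a saturated chain carbon bound to a carbonyl carbon. Within the data shown here, no measured step bears on this exchange, so a step of uncertain direction, within or near the scatter, is expected. Compound 3 is estimated at 1200 nM (range 400 nM to 3600 nM), a step of a 2.2-fold higher number from compound 2 to compound 3 (0.34 log units; beyond the scatter).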

Compound 3, half-maximal inhibitory concentration: 350 nM
Beside the measured number, compound 3's estimate is 3.4-fold (0.54 log units) above it; measured number below the stated range.
By their numbers in this assay, from the lowest: compounds 3 and 2 (each within the scatter of the next); then compound 1.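

Acetoxy in place of chloro on a saturated chain carbon bound to a carbonyl carbon gives, in this assay, a 1.6-fold lower number from compound 2 to compound 3 (0.20 log units; within the scatter) and so no separation between the two groups, which means the chlorine is not needed for the number reached here. With an 8.6-fold lower number from compound 1 to compound 3 (0.93 log units; beyond the scatter) on adding the (acetoxymethyl)carbonyl group, the drop seen with (chloromethyl)carbonyl is not confined to that one group.

No measurement here offers a reason for either step.

From the compounds shown here alone, whether an amine, a carboxylic acid or a longer chain on that carbon would hold the number stays open, as does the plain acetyl group with only hydrogens there.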